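Chloropyridinyl Replaces Phenyl on the Amide Carbonyl

The source may report more compounds than this note shows. Statements on the series, on what has been measured and on what is new or still open speak of the compounds shown alone.

Three amides share one core: compound 1 `Cc1cc(C(=O)NCN2CCC(c3cccc[n+]3[O-])CC2)ccc1F`, compound 2 `O=C(NCN1CCC(c2cccc[n+]2[O-])CC1)c1ccccc1` and compound 3 `Cc1cc(NC(=O)CN2CCC(c3cccc[n+]3[O-])CC2)ccc1F`. In a functional assay on HEK293 cells for agonist activity at D(4) dopamine receptor (Homo sapiens), read by FLIPR (a lower number here means that less compound is needed, a higher number that more compound is needed for the effect), compound 1 gives 50 nM, compound 2 gives 532 nM and compound 3 gives 18 nM. Compound 2 thus stands at the highest number of the three, needing the most compound. Among the compounds with values here, the one step that bears on the aryl group on the carbonyl carbon is an 11-fold higher number from compound 1 to compound 2 (1.03 log units; beyond the scatter), a large change. Compound 4 `O=C(NCN1CCC(c2cccc[n+]2[O-])CC1)c1cnccc1Cl` is not yet measured and differs from compound 2 by 4-chloropyridin-3-yl in place of phenyl on a carbonyl carbon. A substituted ring returns, as in compound 1 with its 50 nM, so a lower number than for compound 2 is expected, with wide uncertainty. Compound 4 is estimated at 250 nM (from 60 nM to 1200 nM), a step of a 2.1-fold lower number from compound 2 to compound 4 (0.33 log units; beyond the scatter).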

Compound 4, half-maximal effective concentration: 1290 nM
Compound 4: the middle estimate sits 5.2-fold (0.71 log units) below what was measured; the whole stated range lies below it.
By their numbers in this assay, from the lowest: compound 3; then compound 1; then compound 2; then compound 4.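

In this assay a substituent on the ring does not by itself lower the number: 4-chloropyridin-3-yl in place of phenyl on the carbonyl carbon gives a 2.4-fold higher number from compound 2 to compound 4 (0.38 log units; beyond the scatter) and so a modest loss. Set against the other substituted ring, this change gives a 26-fold higher number from compound 1 to compound 4 (1.41 log units; beyond the scatter) as a large step, so this position separates 4-chloropyridin-3-yl from 4-fluoro-3-methylphenyl. No measurement here explains this difference. The compounds shown do not separate the effect of the ring nitrogen from that of the chlorine. A plain pyridin-3-yl or a chlorophenyl group on the carbonyl carbon would separate them.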